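Replacing the acylcarbamoyl group on a protected bicyclic nucleoside

The source may report more compounds than this note shows. Statements on the series, on what has been measured and on what is new or still open speak of the compounds shown alone.

Compound 3 `C=C(C)C(=O)NC(=O)NC1=CS(=O)(=O)O[C@@]12[C@@H](CO[Si](C)(C)C(C)(C)C)O[C@@H](n1cc(C)c(=O)n(C)c1=O)[C@@H]2O[Si](C)(C)C(C)(C)C` gives 20000 nM in a functional assay on HEL cells (Homo sapiens) for cytotoxicity, read by microscopy (on this read-out lower numbers stand for higher toxicity in this test and higher numbers for lower toxicity in this test), the lowest of the two numbers shown. Compound 1 `Cc1cn([C@@H]2O[C@H](CO[Si](C)(C)C(C)(C)C)[C@@]3(OS(=O)(=O)C=C3NCC(=O)O)[C@H]2O[Si](C)(C)C(C)(C)C)c(=O)n(C)c1=O` gives 300000 nM, and the step of a 15-fold lower number from compound 1 to compound 3 (1.18 log units; beyond the scatter) came with ((1-methylethenyl)carbonyl)carbamoyl in place of carboxymethyl on an amine nitrogen. Compound 2 `Cc1cn([C@@H]2O[C@@H]3COC(=O)[C@]3(OS(C)(=O)=O)[C@H]2O)c(=O)[nH]c1=O` reaches only a limit of the assay, >= 400000 nM, so no number exists for it; this is the limit of >= 400000 nM in this assay, at which 1 of the 3 values shown sits. Compound 4 `COC(=O)CC(=O)NC1=CS(=O)(=O)O[C@@]12[C@@H](CO[Si](C)(C)C(C)(C)C)O[C@@H](n1cc(C)c(=O)n(C)c1=O)[C@@H]2O[Si](C)(C)C(C)(C)C` differs from compound 3 by (methoxycarbonyl)methyl in place of ((1-methylethenyl)carbonyl)amino on a carbonyl carbon. Going by the values given here, only the step from compound 1 to compound 3 bears on this exchange: that step introduced the ((1-methylethenyl)carbonyl)amino portion which now leaves, so a move back toward a higher number is expected. Compound 4 is therefore expected at 100000 nM, between 20000 nM and 400000 nM. The expected step is a 5.0-fold higher number from compound 3 to compound 4 (0.70 log units; beyond the scatter).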

Compound 4, minimum cytotoxic concentration: 400000 nM
Compound 4: middle estimate off by 4.0-fold (0.60 log units), on the low side, within the range that was stated.
By their numbers in this assay, from the lowest: compound 3; then compounds 1 and 4 (each within the scatter of the next).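

In this assay, not every larger group on this amine nitrogen lowers the number: ((methoxycarbonyl)methyl)carbonyl in place of ((1-methylethenyl)carbonyl)carbamoyl gives a 20-fold higher number from compound 3 to compound 4 (1.30 log units; beyond the scatter). Set against carboxymethyl, the same group gives a 1.3-fold higher number from compound 1 to compound 4 (0.12 log units; within the scatter), so the low number so far belongs to compound 3 alone. Nothing measured here explains this difference.

Which part of the ((1-methylethenyl)carbonyl)carbamoyl group matters remains open. A 2-methylpropanoyl group in place of the 1-methylethenyl carbonyl portion, or a plain carbamoyl group, would help separate the double bond from the rest.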